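The source may hold more compounds than are shown below. What is called first, only, known or untested is meant among the compounds shown, and "the series" means these compounds.

Values measured in a physicochemical assay for solubility; on this read-out lower numbers stand for lower solubility and higher numbers for higher solubility:
- Compound 1 `CNC(=O)c1cc(C(=O)NCCCC2CNCCO2)cn(Cc2ccccc2)c1=O`: >= 194 ug/mL
- Compound 2 `CNC(=O)c1cc(C(=O)NC2CCC2)cn(Cc2ccccn2)c1=O`: >= 103 ug/mL
- Compound 3 `CNC(=O)c1cc(C(=O)NC2CC2)cn(Cc2cccc3c2CCN3)c1=O`: >= 184 ug/mL

Each of these three values is a limit of the assay and not a number, so no ranking of the compounds can be read from them. Compound 2, the starting point here, is no exception: its >= 103 ug/mL is a limit.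

Compound 4 `CNC(=O)c1cc(C(=O)NC2CCC2)cn(Cc2cccnc2)c1=O` has the same atoms as compound 2, joined differently. It carries pyridin-3-yl in place of pyridin-2-yl on a saturated chain carbon bound to an aromatic nitrogen. The same difference can be read as (pyridin-2-yl)methyl to (pyridin-3-yl)methyl.

Among the measured compounds shown here, no pair of measured compounds shows what a change of this kind does. The expectation therefore rests on compound 2 alone, with its limit of >= 103 ug/mL. No shift in either direction beyond the usual scatter is expected, and the estimated change is small: a step that the limit leaves unreadable from compound 2 to compound 4. In this assay the estimate for compound 4 is 120 ug/mL, expected to fall between 70 ug/mL and 190 ug/mL.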

Compound 4, solubility: >= 99 ug/mL
Compound 4 was reported as a limit; the forecaster's own chance of this, stated with the estimate: 70%; the middle value is on the limit's open side.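

In this assay compound 4 gives >= 99 ug/mL, which is a limit. Compound 2 gives >= 103 ug/mL, also a limit. Among the compounds shown here, no step between compound 2 and compound 4 can therefore be read. The compounds shown leave open whether pyridin-3-yl in place of pyridin-2-yl changes solubility at all.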